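A few compounds are considered here, and "the series" means these few. Any claim that something is new, unique, unknown or untested is made for them only; others in the source may bear on it.

Among the compounds with values here, in an assay on HEK293 cells for inhibition of acid ceramidase (Homo sapiens), read by fluorescence, with stated times of 10 min and 3 h (on this read-out lower numbers stand for stronger inhibition and higher numbers for weaker inhibition), compound 3 `CC(C)CNC(=O)n1c(=O)oc2cc(C3CCN(C)CC3)ccc21` gives 166 nM, the second highest of the three numbers measured so far; compound 2 `CCCCCNC(=O)n1c(=O)oc2cc(-c3ccc(F)cc3)ccc21` gives 60 nM, and compound 1 `CCC(C)NC(=O)n1c(=O)oc2cc(C3CCN(C)CC3)ccc21` gives 2100 nM. Compound 4 `CCCCCNC(=O)n1c(=O)oc2cc(C3CCN(C)CC3)ccc21` differs from compound 3 by butyl in place of isopropyl on a saturated chain carbon bound to an amide-type nitrogen, which read one bond further out is isobutylcarbamoyl to pentylcarbamoyl. Within the data shown here, only one measured step touches this chain: a 13-fold lower number from compound 1 to compound 3 (1.10 log units; beyond the scatter). That step was large, but it compares two branched chains and not a branched with a straight one. Compound 2 carries the same pentyl chain on a different core and shows the lowest of the three numbers with 60 nM, though it departs from compound 4 in more than one place. On this basis compound 4 is expected to give a somewhat lower number than compound 3, an estimated step of a 2.1-fold lower number from compound 3 to compound 4 (0.32 log units; beyond the scatter). The estimate for compound 4 in this assay is 80 nM, within a range of 25 nM to 250 nM.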

Compound 4, half-maximal inhibitory concentration: 396 nM
Beside the measured number, compound 4's estimate is 5.0-fold (0.69 log units) below it; measured number above the stated range.
By their numbers in this assay, from the lowest: compound 2; then compound 3; then compound 4; then compound 1.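

On the shared core, lengthening the chain on the amide-type nitrogen to straight pentyl did not beat the branched isobutyl (a 2.4-fold higher number from compound 3 to compound 4 (0.38 log units; beyond the scatter)), although pentyl still improved on sec-butyl (a 5.3-fold lower number from compound 1 to compound 4 (0.72 log units; beyond the scatter)); this places the three chains in the order isobutyl, pentyl, sec-butyl, from lowest number to highest. With pentyl held fixed, 1-methylpiperidin-4-yl in place of 4-fluorophenyl on an aromatic carbon gave a higher number (a 6.6-fold higher number from compound 2 to compound 4 (0.82 log units; beyond the scatter)), which shows that the low number of compound 2 does not come from the pentyl chain alone. No measurement shown accounts for these differences.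

From the compounds shown here alone, it remains open whether isobutyl would also give a lower number than pentyl with 4-fluorophenyl on the aromatic carbon. Nor do the compounds shown tell how a hexyl chain or a cyclohexylmethyl group would fare on the amide-type nitrogen.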